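A few compounds are considered here, and "the series" means these few. Any claim that something is new, unique, unknown or untested is made for them only; others in the source may bear on it.

Working notes on the series built on the core of compound 1 `O=C1NCCN1c1ccc(S(=O)(=O)Nc2ccc(I)cc2)cc1`. In a functional assay on M21 cells (Homo sapiens) for antiproliferative activity, read by sulforhodamine B assay, with a stated time of 48 h (a lower number here means a stronger inhibitor, a higher number a weaker inhibitor), compound 1 gives 260 nM, compound 2 `Cc1cccc(NS(=O)(=O)c2ccc(N3CCNC3=O)cc2)c1C` gives 110 nM and compound 3 `Cc1ccc(C)c(NS(=O)(=O)c2ccc(N3CCNC3=O)cc2)c1` gives 27 nM. Compound 3 therefore holds the lowest number of the three, and its gaps to both of the others lie beyond the scatter.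

The next compound is compound 4 `COc1ccc(NS(=O)(=O)c2ccc(N3CCNC3=O)cc2)cc1`, which carries 4-methoxyphenyl in place of 2,5-dimethylphenyl on a sulfonamide nitrogen.

Among the measured compounds shown here, three measured steps bear on this change, all of them at the same sulfonamide nitrogen. Both steps that arrive at 2,5-dimethylphenyl lower the number: a 9.6-fold lower number from compound 1 to compound 3 (0.98 log units; beyond the scatter) and a 4.1-fold lower number from compound 2 to compound 3 (0.61 log units; beyond the scatter). The remaining step, a 2.4-fold lower number from compound 1 to compound 2 (0.37 log units; beyond the scatter), is smaller. For the measured compounds named here, compound 1 is the nearest comparison, as its 4-iodophenyl is the only measured group with the same 4-position naming as 4-methoxyphenyl. Going by the values given here, no measured compound carries a methoxy group, so the size of the step remains poorly defined.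

Leaving 2,5-dimethylphenyl is expected to raise the number in this assay, with an estimated change of a 7.4-fold higher number from compound 3 to compound 4 (0.87 log units; beyond the scatter), comparable to the two steps above and beyond the scatter. For compound 4 the estimated value is 200 nM, with an expected range of 60 nM to 650 nM.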

Compound 4, half-maximal inhibitory concentration: 580 nM
Compound 4: the middle estimate sits 2.9-fold (0.46 log units) below what was measured; the range from low to high includes it.
By their numbers in this assay, from the lowest: compound 3; then compound 2; then compound 1; then compound 4.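

Leaving 2,5-dimethylphenyl for 4-methoxyphenyl in this assay produces the largest step so far at this sulfonamide nitrogen (a 21-fold higher number from compound 3 to compound 4 (1.33 log units; beyond the scatter)), and compound 4 now has the highest number of the four, so this position can move the number upward as well as downward. The same group also compares unfavourably with 2,3-dimethylphenyl (a 5.3-fold higher number from compound 2 to compound 4 (0.72 log units; beyond the scatter)), which places both dimethylphenyl compounds below both compounds with a single group on the ring, with no exception among these four. Methoxy in place of iodo on an aromatic carbon gives the smallest of the new steps (a 2.2-fold higher number from compound 1 to compound 4 (0.35 log units; beyond the scatter)), so the choice between these two groups matters less here than the change from 2,5-dimethylphenyl, although it still lies beyond the scatter.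

The compounds shown leave open whether the low number of compound 3 depends on its two methyl groups specifically or would persist with 2,5-dimethoxyphenyl, 2,5-dichlorophenyl or a ring bearing an amine or a carboxylic acid. Nothing available here accounts for the size of these steps.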